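Compound 4 Follows Compound 3 in Maximal Response

The compounds below may be only part of what the source reports. "The series", "measured", "known", "first", "only" and "open" are said of these compounds alone.

Measured compounds and their values:
- compound 1, `O=C(O)Cc1sc(CSc2ccccc2)nc1-c1ccc(Cl)cc1`, 50%
- compound 2, `O=C(O)Cc1sc(C(c2ccccc2)c2ccc(O)cc2)nc1-c1ccc(F)cc1`, 80%
- compound 3, `O=C(O)Cc1sc(C(c2ccc(F)cc2)c2ccc(F)cc2)nc1-c1cc(F)cc(F)c1`, 80%

In an in vitro functional assay on HEK285-7 cells for antagonist activity at prostaglandin D2 receptor 2 (Homo sapiens), read by BRET and beta-arrestin recruitment (a higher number here means a larger maximal response, a lower number a smaller maximal response), compound 3 gives 80%. Among the three numbers this is level with compound 2 at the digits shown, the two together being the highest; compound 3 and compound 2 lie within the scatter of each other, so no order between them can be claimed. The furthest number is that of compound 1, which in this assay gives 50%, a value that sits well below compound 3, beyond the scatter.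

Compound 4, `CN(C)c1cc(-c2nc(C(c3ccc(F)cc3)c3ccc(F)cc3)sc2CC(=O)O)ccn1`, differs from compound 3 in one place:
2-(dimethylamino)pyridin-4-yl in place of 3,5-difluorophenyl on an aromatic carbon
The carboxymethyl group and the diarylmethyl group on the other side of the core are kept unchanged. For the measured compounds named here, no measured pair shows this kind of exchange, so its effect is unknown. Since compound 2 and compound 3 both reach a high maximal response with different aromatic groups at this place, the expectation is a step from compound 3 to compound 4 of a number 5 percentage points lower from compound 3 to compound 4 (within the scatter), none beyond the scatter. For compound 4 the estimated value in this assay is 75%, with a range from 50% to 95%.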

Compound 4, largest response reached (reported as efficacy), in percent of the reference or control that the assay uses: 80%
For compound 4 the middle estimate is 5 percentage points below the measured one; the range from low to high includes it.
By their numbers in this assay, from the lowest: compound 1; then compounds 2, 3 and 4 (each within the scatter of the next).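

In this assay, putting 2-(dimethylamino)pyridin-4-yl in place of 3,5-difluorophenyl gives no change at the digits printed from compound 3 to compound 4 (within the scatter). This is the only one-place exchange shown at this aromatic carbon, which stands next to the ring nitrogen and next to the ring atom that bears a carboxymethyl group, and it shows that a ring with 1 hetero atom and 2 hydrogen-bond acceptors can replace a carbon-only ring carrying fluorine with no measurable shift in maximal response. Nothing measured here speaks to the reason for this result.

The compounds shown leave open whether the ring nitrogen or the dimethylamino group matters more for this outcome, a question that a plain pyridin-4-yl or a 2-aminopyridin-4-yl at the same place could help separate. Also open, as far as these compounds go, is whether the maximal response would hold with a non-aromatic group here, such as a piperidine or a longer chain ending in an amine, and whether the same exchange would behave alike with a different group on the other side of the shared core.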